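Aryl thioether propargylamines: trifluoromethyl for chloro

This account rests on a few compounds, and the source may have more. Where it says the series, first, only, none or still open, it means among the compounds named here.

Measured compounds:
compound 1 `C#CCNC1CCc2c(SCCc3cccc(Cl)c3)cccc21` — "not determined" (no result reported)
compound 2 `C#CCNC1CCc2c(SCCc3ccc(F)c(F)c3)cccc21` — "not determined" (no result reported)
compound 3 `C#CCNC1CCc2c(SCCc3ccc(Cl)c(Cl)c3)cccc21` — 2820 nM

In an ADME assay on isolated protein for inhibition of Amine oxidase [flavin-containing] B (Homo sapiens) (on this read-out higher numbers stand for weaker inhibition and lower numbers for stronger inhibition), compound 3 alone gives a number, 2820 nM. Compound 1 has no single number in this assay, and compound 2 likewise stands without one, so compound 1 cannot be placed against the others on the numbers shown. Compound 4 `C#CCNC1CCc2c(SCCc3cccc(C(F)(F)F)c3)cccc21` differs from compound 1 by trifluoromethyl in place of chloro on an aromatic carbon. Among the compounds with values here, no step between measured compounds covers this change, and with nothing measured for compound 1 the only anchor is the value of compound 3. A step in this assay is expected to be small, within the usual scatter and without a preferred direction. For compound 4 the half-maximal inhibitory concentration is estimated at 2500 nM, with a range from 600 nM to 10000 nM.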

Compound 4, half-maximal inhibitory concentration: 280 nM
Compound 4: the middle estimate sits 8.9-fold (0.95 log units) above what was measured; measured number outside the range, below it.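

Within the data shown here, compound 1 has no single number, so no step to compound 4 can be read. Whether trifluoromethyl in place of chloro strengthens or weakens inhibition stays open, and nothing shown explains the result.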